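A few compounds are considered here, and "the series" means these few. Any claim that something is new, unique, unknown or untested is made for them only; others in the source may bear on it.

Compound 1 `CSc1nc(NCCCCNc2ccnc3cc(Cl)ccc23)c(C#N)c(-c2ccccc2)n1` stands level with its nearest neighbour in an ADME assay on HeLa cells (Homo sapiens) for cytotoxicity, read by microscopy (a higher number here means that more compound is tolerated, a lower number that less compound is tolerated), where compound 1 gives 100000 nM. Compound 2 `CSc1nc(NCCCCNc2ccnc3cc(Cl)ccc23)c(C#N)c(-c2cccc([N+](=O)[O-])c2)n1` carries a nitro group and gives 100000 nM in this assay, and the step of no change at the digits printed from compound 1 to compound 2 (within the scatter). Compound 3 `CSc1nc(-c2ccc([N+](=O)[O-])cc2)c(C#N)c(N2CCN(c3ccnc4cc(Cl)ccc34)CC2)n1` is reported in this assay only as a limit, > 100000 nM. That entry is the limit of > 100000 nM in this assay, at which 1 of the 3 values shown sits. Compound 4 `CSc1nc(NCCCCNc2ccnc3cc(Cl)ccc23)c(C#N)c(-c2ccc(C)cc2)n1` is not yet measured; it differs from compound 1 by methyl in place of hydrogen on an aromatic carbon, phenyl to 4-methylphenyl. Going by the values given here, the only measured single change on this ring, the nitro step, lies within the scatter, so one expects no change at the digits printed from compound 1 to compound 4 (within the scatter), nothing beyond the scatter. Compound 4 is therefore estimated to give 100000 nM in this assay, within 50000 nM to 200000 nM.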

Compound 4, minimum cytotoxic concentration: 100000 nM
For compound 4 middle estimate and measured number coincide at the digits printed, within the range that was stated.
By their numbers in this assay, from the lowest: compounds 1, 2 and 4 (each within the scatter of the next).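

Methyl on the aromatic carbon para to a large group brings no change at the digits printed from compound 1 to compound 4 (within the scatter) in this assay. Exchanging 3-nitrophenyl for 4-methylphenyl brings no change at the digits printed from compound 2 to compound 4 (within the scatter), so this ring now carries a second kind of substituent with the same printed number. Compound 3 is reported only as a limit: the limit of > 100000 nM in this assay, at which 1 of the 4 values shown sits.

As far as these compounds go, what an amine or a carboxylic acid on this ring would do remains open, as does a longer chain in place of the present one. The compounds shown include no change on this ring that moves the number beyond the scatter.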